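The source may hold more compounds than are shown below. What is called first, only, known or untested is meant among the compounds shown, and "the series" means these compounds.

Among the compounds with values here, in an ADME assay on microsomes from liver (Rattus norvegicus, strain Sprague-Dawley) for metabolic stability, read by HPLC, using NADPH, with stated times of 5 min and 60 min, tested at 10 uM (on this read-out lower numbers stand for slow clearance and higher numbers for fast clearance), compound 2 `CS(=O)(=O)Nc1ccc(CNC(=O)c2ccc(N3CCC3)cc2)c(Cl)c1` gives 8.6 mL.min-1.g-1, the lower of the two numbers measured so far, while compound 1 `CC(C)S(=O)(=O)Nc1ccc(CNC(=O)c2ccc(C(C)(C)C)cc2)c(Cl)c1` gives 23 mL.min-1.g-1, a gap wider than the usual scatter between repeated measurements. Compound 3 `CS(=O)(=O)Nc1ccc(CNC(=O)c2ccc(S(F)(F)(F)(F)F)cc2)c(Cl)c1` has not yet been measured. It differs from compound 2 in a single place: a group of 6 heavy atoms (5 fluorine, 1 sulfur; no ring) in place of a group of 4 heavy atoms (3 carbon, 1 nitrogen; one four-membered non-aromatic ring with 1 hetero atom), on an aromatic carbon. Within the data shown here, no measured pair shows this kind of change, so the expectation is a modest upward step, a 1.4-fold higher number from compound 2 to compound 3 (0.14 log units; within the scatter), of a size that may still sit within the scatter. On that basis compound 3 is expected to give about 12 mL.min-1.g-1, with a likely range from 5 mL.min-1.g-1 to 30 mL.min-1.g-1.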

Compound 3, intrinsic clearance in microsomes: 9.8 mL.min-1.g-1
Beside the measured number, compound 3's estimate is 1.2-fold (0.09 log units) above it; measured number inside the range.
By their numbers in this assay, from the lowest: compounds 2 and 3 (each within the scatter of the next); then compound 1.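

In this assay, putting the fluorine-and-sulfur group in place of azetidin-1-yl, on an aromatic carbon para to a large group, gives a 1.1-fold higher number from compound 2 to compound 3 (0.06 log units; within the scatter), so the two numbers cannot be told apart. At this position, then, a group with a ring and nitrogen and a group with no ring and no nitrogen read alike. No measurement on hand accounts for this result. From the compounds shown here alone, whether a carboxylic acid, a primary amine or a longer chain such as n-butyl would read the same at this position remains open.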